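The compounds below may be only part of what the source reports. "The series", "measured", "known", "first", "only" and "open" are said of these compounds alone.

Three compounds on the shared core have numbers in a functional assay on SW480 cells (Homo sapiens) for antiproliferative activity, read by MTT assay, with a stated time of 48 h; a higher number here means a weaker inhibitor, a lower number a stronger inhibitor: compound 1 `CCN(CC)C/C1=C/C[C@](C)(CCC=C(C)C)/C=C/[C@@H](OC(=O)C=C(C)C)[C@](C)(O)/C=C/C1=O` gives 270 nM, compound 2 `CC(C)=CCC[C@]1(C)/C=C/[C@@H](OC(=O)C=C(C)C)[C@](C)(O)/C=C/C(=O)/C(CN2CCN(C)CC2)=C\C1` gives 800 nM, and compound 3 `CC(C)=CCC[C@]1(C)/C=C/[C@@H](OC(=O)C=C(C)C)[C@](C)(O)/C=C/C(=O)/C(C[Si](C)(C)C(C)(C)C)=C\C1` gives 3350 nM. Compound 3 therefore has the highest number of the three and is the weakest inhibitor so far.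

Compound 4 `CO/N=C/C1=C/C[C@](C)(CCC=C(C)C)/C=C/[C@@H](OC(=O)C=C(C)C)[C@](C)(O)/C=C/C1=O` differs from compound 3 by a group of 4 heavy atoms (2 carbon, 1 nitrogen, 1 oxygen; no ring) in place of a group of 8 heavy atoms (7 carbon, 1 silicon; no ring), on a double-bonded ring carbon.

Two measured steps end at compound 3 and start from the group it would lose in comparison: a 12-fold higher number from compound 1 to compound 3 (1.09 log units; beyond the scatter), a large step, and a 4.2-fold higher number from compound 2 to compound 3 (0.62 log units; beyond the scatter), a modest one. The step of a 3.0-fold higher number from compound 1 to compound 2 (0.47 log units; beyond the scatter) is also modest and shows that the two compounds without silicon differ from each other as well. None of these steps tests the group entering in compound 4, so they bear on it only indirectly. Both compounds without silicon sit lower than compound 3, but two compounds are thin evidence.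

A modest fall in the number is expected, with a real chance of little change. The estimated step is a 2.8-fold lower number from compound 3 to compound 4 (0.45 log units; beyond the scatter). Compound 4 is expected at 1200 nM, with an estimated range of 350 nM to 4000 nM.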

Compound 4, half-maximal inhibitory concentration: 2630 nM
The estimate for compound 4 lay 2.2-fold (0.34 log units) below the measured number; low and high end bracket the measured number.
By their numbers in this assay, from the lowest: compound 1; then compound 2; then compounds 4 and 3 (each within the scatter of the next).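

In this assay, a 1.3-fold lower number from compound 3 to compound 4 (0.11 log units; within the scatter) shows that at this double-bonded ring carbon, exchanging the silicon-bearing group of 8 heavy atoms for a group of 4 heavy atoms with nitrogen and oxygen does not separate the two compounds, so the absence of silicon alone does not bring the number down to those of compound 1 and compound 2. The same entering group stays clearly apart from the two amines, with a 3.3-fold higher number from compound 2 to compound 4 (0.52 log units; beyond the scatter) and a 9.7-fold higher number from compound 1 to compound 4 (0.99 log units; beyond the scatter), so among these four compounds the lower numbers go with the diethylamino and 4-methylpiperazin-1-yl groups on a saturated chain carbon, and no compound shown goes against this. Nothing measured here explains these differences.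

The compounds shown leave open how a morpholin-4-yl or dimethylamino group, or a carboxylic acid, would read at this place on the shared core. They also leave open whether a longer chain between the double-bonded ring carbon and the diethylamino group would keep the number that compound 1 gives, 270 nM.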